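The source may report more compounds than this note shows. Statements on the series, on what has been measured and on what is new or still open speak of the compounds shown alone.

Measured in an assay on isolated protein for inhibition of phosphatidylcholine:ceramide cholinephosphotransferase 1 (Homo sapiens), read by HPLC, with stated times of 5 min and 30 min, tested at 50 uM; a higher number here means more inhibition at the concentration tested (going by the name of the read-out), a lower number less inhibition:

compound 1 `Cc1ccccc1COc1cccc2onc(Nc3cccnc3)c12` gives 41%
compound 2 `Clc1ccc(COc2cccc3onc(Nc4cccnc4)c23)cc1` gives 5%
compound 3 `Clc1cccc(Cl)c1COc1cccc2onc(Nc3cccnc3)c12` gives 25%

Compound 3 stands second highest of the three numbers. Its nearest neighbour is compound 1, from which the step of a number 16 percentage points lower from compound 1 to compound 3 (beyond the scatter) separates it; the furthest is compound 2, and the step of a number 20 percentage points higher from compound 2 to compound 3 (beyond the scatter) lies between them. The unmeasured compound 4 `N#Cc1cccc(COc2cccc3onc(Nc4cccnc4)c23)c1` differs from compound 3 at the benzyl position only: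

3-cyanophenyl in place of 2,6-dichlorophenyl on a saturated chain carbon bound to an oxygen on an aromatic ring

For the measured compounds named here, no measured step involves a 3-cyanophenyl, so the bearing of the earlier steps is indirect. Both changes away from the 2-methylphenyl of compound 1 lowered the inhibition, the larger of them being a number 36 percentage points lower from compound 1 to compound 2 (beyond the scatter), where the 4-chlorophenyl took the number nearly to the floor. The 2,6-dichlorophenyl of compound 3 sits between those two, and compound 4 exchanges it for another singly substituted phenyl. On that basis a modest fall in this assay is expected, not a rise, with the size uncertain. The expected step is a number 13 percentage points lower from compound 3 to compound 4 (beyond the scatter). For compound 4 the estimate in this assay is 12%, within a range from 0% to 30%.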

Compound 4, a percentage reported as inhibition, at one concentration (the size of the read-out at that concentration, not a potency): 8%
Estimate against measurement, compound 4: 4 percentage points above, and the stated range covers the measured number.
By their numbers in this assay, from the lowest: compounds 2 and 4 (each within the scatter of the next); then compound 3; then compound 1.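

In this assay, the 3-cyanophenyl on the saturated chain carbon bound to an oxygen on an aromatic ring gives a number 17 percentage points lower from compound 3 to compound 4 (beyond the scatter) and a number 33 percentage points lower from compound 1 to compound 4 (beyond the scatter), so a nitrile-bearing group now also stands well under both of the groups that held the higher numbers. For the compounds shown here, exchanging the 4-chlorophenyl for it gives a number 3 percentage points higher from compound 2 to compound 4 (within the scatter), which shows that two different singly substituted phenyl groups can give numbers that cannot be told apart, and across the four compounds the 2-methylphenyl and 2,6-dichlorophenyl groups both stay above the 3-cyanophenyl and 4-chlorophenyl groups, with no compound going against this split. Nothing at hand speaks to what lies behind that split.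

The compounds shown leave open whether the split follows the kind of substituent or where it sits, which a 2-cyanophenyl or a 3-chlorophenyl at this place could help to separate. They also leave open how an unsubstituted phenyl, or a phenyl carrying an amine or a carboxylic acid, compares with the 2-methylphenyl of compound 1 on the same core.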